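Urea series on the shared core: trifluoromethylphenyl replaces hydroxyphenyl-semicarbazide

The source may report more compounds than this note shows. Statements on the series, on what has been measured and on what is new or still open speak of the compounds shown alone.

Measured compounds in a functional assay on NCI-H460 cells (Homo sapiens) for inhibition, read by MTT assay, with a stated time of 72 h; on this read-out higher numbers stand for weaker inhibition and lower numbers for stronger inhibition: compound 1 `COc1cc(NC(C)CCCNC(=O)Nc2ccc(F)cc2)c2ncccc2c1` gives 26000 nM. Compound 2 `COc1cc(NC(C)CCCNC(=O)Nc2ccc(C(F)(F)F)cc2)c2ncccc2c1` gives 24000 nM. Compound 3 `COc1cc(NC(C)CCCNC(=O)NNC(=O)Nc2ccc(O)cc2)c2ncccc2c1` gives > 100000 nM, which is a limit of the assay and not a number.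

Among the compounds with values here, compound 3 thus stands at the weak end of the three, with only a limit known, the one value at the limit of > 100000 nM in this assay, at which 1 of the 3 values shown sits. Compound 4 `COc1cc(NC(C)CCCNC(=O)Nc2cccc(C(F)(F)F)c2)c2ncccc2c1` differs from compound 3 in one place: 3-(trifluoromethyl)phenyl in place of ((4-hydroxyphenyl)carbamoyl)amino on an amide-type nitrogen.

Within the data shown here, two measured steps bear on this change, both running the other way. The step of an at least 3.8-fold higher number from compound 1 to compound 3 (0.58 log units; beyond the scatter) and the step of an at least 4.1-fold higher number from compound 2 to compound 3 (0.61 log units; beyond the scatter) were each beyond the scatter, so removing the ((4-hydroxyphenyl)carbamoyl)amino group in favour of an aryl group is expected to bring the number back down. Between the two aryl groups already seen, a 1.1-fold lower number from compound 1 to compound 2 (0.03 log units; within the scatter) was within the scatter, so the trifluoromethyl placement is not expected to matter much on its own.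

Compound 4 is therefore expected to land near compound 2, with an estimate of 25000 nM, within 10000 nM to 70000 nM, which means an expected step of an at least 4.0-fold lower number from compound 3 to compound 4 (0.60 log units; beyond the scatter).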

Compound 4, half-maximal inhibitory concentration: 21000 nM
Estimate against measurement, compound 4: 1.2-fold (0.08 log units) above; low and high end bracket the measured number.
By their numbers in this assay, from the lowest: compounds 4, 2 and 1 (each within the scatter of the next). At a limit, above all of these: compound 3.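

In this assay, 3-(trifluoromethyl)phenyl in place of ((4-hydroxyphenyl)carbamoyl)amino on the amide-type nitrogen gives an at least 4.7-fold lower number from compound 3 to compound 4 (0.67 log units; beyond the scatter). Compound 3 holds only a limit of the assay, not a number: the limit of > 100000 nM in this assay, at which 1 of the 4 values shown sits. The aryl ureas stay together whichever of these groups is present, with a 1.1-fold lower number from compound 2 to compound 4 (0.06 log units; within the scatter) for 3-(trifluoromethyl)phenyl in place of 4-(trifluoromethyl)phenyl and a 1.2-fold lower number from compound 1 to compound 4 (0.09 log units; within the scatter) for 3-(trifluoromethyl)phenyl in place of 4-fluorophenyl.

Compound 3 differs from the aryl ureas in both its hydroxyl and its extra carbamoyl-amino link, and the compounds shown do not separate these two parts. Also open, on these data alone, is whether an aryl ring bearing an amine or a carboxylic acid, or a longer chain on the shared core, would leave the values of this group of ureas.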